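The compounds below may be only part of what the source reports. "The series", "measured", "known", "first", "only" and "open" are said of these compounds alone.

Among the compounds with values here, in an ADME assay on L929 cells (Mus musculus) for cytotoxicity, read by resazurin assay, with a stated time of 72 h (on this read-out higher numbers stand for weaker inhibition and lower numbers for stronger inhibition), compound 2, `Nc1ccc(C(=O)c2ccn(-c3ccc4c(c3)B(O)OC4)c2)cc1`, gives 3.9 ug/mL, the only definite number among the two values that have been recorded. Its methoxy counterpart, compound 1, `COc1ccc(C(=O)c2ccn(-c3ccc4c(c3)B(O)OC4)c2)cc1`, is known in this assay only by a limit of > 10 ug/mL. Within the data shown here, the one comparison available, an at least 2.5-fold lower number from compound 1 to compound 2 (0.40 log units; beyond the scatter), therefore rests on one side against the limit of > 10 ug/mL in this assay, at which 1 of the 2 values shown sits, and sets only a floor on how far the amino compound falls below the methoxy one.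

Compound 3, `NCCCC(=O)c1ccn(-c2ccc3c(c2)B(O)OC3)c1`, changes a different part of the molecule: 3-aminopropyl in place of 4-aminophenyl on a carbonyl carbon. The aryl ketone of compound 2 becomes an alkyl ketone carrying the same amine at the end of a three-carbon chain, while the boron-containing heterocycle and the pyrrole are kept. Among the measured compounds shown here, no recorded step bears directly on the loss of the aromatic ring from the ketone; the only step known, an at least 2.5-fold lower number from compound 1 to compound 2 (0.40 log units; beyond the scatter), concerns a substituent on that ring rather than the ring itself. The account expects that compound 3 gives a higher number, with a 2.1-fold higher number from compound 2 to compound 3 (0.31 log units; beyond the scatter) as the estimated step from compound 2. On that basis compound 3 is estimated at 8 ug/mL in this assay, within 3 ug/mL to 20 ug/mL, with a fair chance that only a limit is returned.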

Compound 3, half-maximal inhibitory concentration: > 10 ug/mL
Compound 3: a limit, no number; the forecaster's own chance of this, stated with the estimate: 35%; middle value at least 1.2-fold (0.09 log units) from the limit.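

The result shows that in this assay the group on the carbonyl carbon can be changed as a whole, and not only through a substituent on its ring, with a readable effect: 3-aminopropyl in place of 4-aminophenyl gives an at least 2.5-fold higher number from compound 2 to compound 3 (0.40 log units; beyond the scatter). Compound 2 now stands apart from both other compounds, since keeping the amine without the aromatic ring and keeping the aromatic ring without the amine each end at a limit rather than a number. Neither the true size of this rise nor the step between the two limited compounds can be read, and the reason lies in how many values end at the same ceiling: the limit of > 10 ug/mL in this assay, at which 2 of the 3 values shown sit.

Going by these compounds, what remains open is whether a longer chain ending in the same amine, or a phenyl ring bearing a hydroxyl group, would bring the number back towards that of compound 2, at 3.9 ug/mL. Equally open, on these data alone, is whether an unsubstituted phenyl group on the carbonyl carbon would fall with compound 2 or at the limit reached by compound 3.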